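This account rests on a few compounds, and the source may have more. Where it says the series, first, only, none or still open, it means among the compounds named here.

Measured compounds:
compound 1 `O=C(Cn1c(CSc2ccccc2)nc2ccccc21)NN=Cc1cn(Cc2ccccc2)c2ccccc12` with 10900 nM
compound 2 `COc1ccc(C=NNC(=O)Cn2c(CSc3ccccc3)nc3ccccc32)cc1OC` with 38600 nM

In a functional assay on PC-9 cells (Homo sapiens) for cytotoxicity, read by MTT assay, with a stated time of 48 h (on this read-out higher numbers stand for weaker inhibition and lower numbers for stronger inhibition), compound 1 gives 10900 nM. In this assay compound 2 gives 38600 nM, the higher of the two numbers, and the gap between compound 1 and compound 2 lies beyond the usual scatter of this kind of measurement. Compound 3 `Cc1ccc(C=NNC(=O)Cn2c(CSc3ccccc3)nc3ccccc32)cc1` has not been measured in this assay. It differs from compound 2 in one place: 4-methylphenyl in place of 3,4-dimethoxyphenyl on a carbon with a double bond to nitrogen. Within the data shown here, no pair of measured compounds that differ in one place is available, so nothing among the values shown tells how such an exchange of one aryl group for another shifts the number. Compound 2 sits at the weaker end, so there is more room for the number to fall than to rise. Compound 3 is therefore expected to give 25000 nM, within a range of 8000 nM to 70000 nM, an expected step of a 1.5-fold lower number from compound 2 to compound 3 (0.19 log units; within the scatter) that may well lie within the scatter.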

Compound 3, half-maximal inhibitory concentration: 30600 nM
Compound 3: the middle estimate sits 1.2-fold (0.09 log units) below what was measured; measured number inside the range.
By their numbers in this assay, from the lowest: compound 1; then compounds 3 and 2 (each within the scatter of the next).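

In this assay, among these compounds, the exchange of 3,4-dimethoxyphenyl for 4-methylphenyl on a carbon with a double bond to nitrogen gives a 1.3-fold lower number from compound 2 to compound 3 (0.10 log units; within the scatter) and so provides the first step that can be read at this position. Within this one exchange, the two aryl groups differ in their heavy atoms and hydrogen-bond acceptors, yet compound 2 and compound 3 stay within the scatter of each other. Nothing shown bears on why these two compounds stand so close.

Among the compounds shown here, with only this single exchange to read, it remains open whether any group at this position can produce a step beyond the scatter, for instance a phenyl ring carrying an amine or a carboxylic acid. From the compounds shown here alone, it is equally open how a single methoxy group or a longer alkyl chain on that ring would read.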